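Adding 4-chlorophenyl to a compound at the assay limit

A few compounds are considered here, and "the series" means these few. Any claim that something is new, unique, unknown or untested is made for them only; others in the source may bear on it.

compound 1 `CCCCCCCCc1ccc(OCC(=O)Cn2ncnn2)cc1`: < 5%
compound 2 `CCCCCCCCc1ccc(OCC(=O)Cn2nnc(C)n2)cc1`: < 5%
compound 3 `CCCCCCCCc1ccc(OCC(=O)Cn2nnc(SC)n2)cc1`: < 5%

These three compounds were read in an ADME assay on S9 fraction from liver (Rattus norvegicus) for metabolic stability, read by LC-MS, using NADPH, with a stated time of 30 min; a higher number here means that more of the compound is left, a lower number that less of the compound is left. Compound 1 gives < 5%, which is a limit and not a number. Compound 2 gives < 5%, which is also a limit. Compound 3 gives < 5%, again a limit. All three therefore share one reading: the limit of < 5% in this assay, at which 3 of the 3 values shown sit. Compound 1 thus has no exact position, only this limit.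

Compound 4 `CCCCCCCCc1ccc(OCC(=O)Cn2nnc(-c3ccc(Cl)cc3)n2)cc1` carries 4-chlorophenyl in place of hydrogen on an aromatic carbon.

Among the compounds with values here, three measured steps bear on this change, since each concerns a group on that same aromatic carbon. They are a step that the two limits leave unreadable from compound 1 to compound 2, a step that the two limits leave unreadable from compound 1 to compound 3 and a step that the two limits leave unreadable from compound 2 to compound 3. None of them has a readable size, so they offer no size or direction to carry over to the larger group. With compound 1, compound 2 and compound 3 all at the limit, no step beyond the scatter is expected, and a reading at the same limit is the likeliest outcome. The estimated step is a step that the limit leaves unreadable from compound 1 to compound 4. For compound 4 the expected value is 3%, with an estimated range from 0% to 10%.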

Compound 4, percent of the compound remaining: 74%
Beside the measured number, compound 4's estimate is 71 percentage points below it; measured number above the stated range.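

In this assay, the aromatic carbon of the five-membered ring with 4 nitrogen now proves to be a place where a single change can lift the reading clear of the limit: 4-chlorophenyl in place of hydrogen gives a number at least 69 percentage points higher from compound 1 to compound 4 (beyond the scatter). The same holds against the other two groups on that carbon, with a number at least 69 percentage points higher from compound 2 to compound 4 (beyond the scatter) and a number at least 69 percentage points higher from compound 3 to compound 4 (beyond the scatter), so the change stands out against all three earlier compounds, among which no step could be read. Hydrogen, methyl and methylsulfanyl on this carbon gave no separation, and compound 4 is the only compound here with a reading off the limit, which leaves the size of each step open at its lower end: the limit of < 5% in this assay, at which 3 of the 4 values shown sit.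

The compounds shown leave open whether the chlorine or the phenyl ring carries the rise, a question that a phenyl without chlorine, or with bromine in its place, on the same carbon would address. They also leave open whether 4-chlorophenyl would act in the same way if a shorter chain replaced the long chain of the shared core.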